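Notes on the amine substituent step to compound 3

The compounds below may be only part of what the source reports. "The series", "measured", "known", "first", "only" and "open" are said of these compounds alone.

Compound 2 `Nc1ncnc2c1ncn2[C@@H]1O[C@H](CN(CC[C@H](N)C(=O)O)Cc2ccccc2)[C@@H](O)[C@H]1O` stands highest of the two numbers in an assay for inhibition of tRNA (cytosine(38)-C(5))-methyltransferase (Homo sapiens), with a stated time of 5 min, tested at 100 uM (on this read-out lower numbers stand for less inhibition and higher numbers for more inhibition at the one concentration tested (going by the name of the read-out)), where compound 2 gives 56.8%; compound 1 `Nc1ncnc2c1ncn2[C@@H]1O[C@H](CN(CC[C@H](N)C(=O)O)CC2CC2)[C@@H](O)[C@H]1O` gives 27.5%. Compound 3 `C#CC(C)(C)N(CC[C@H](N)C(=O)O)C[C@H]1O[C@@H](n2cnc3c(N)ncnc32)[C@H](O)[C@@H]1O` is unmeasured and differs from compound 2 by 1,1-dimethylprop-2-yn-1-yl in place of benzyl on an amine nitrogen. Within the data shown here, the only step that bears on this change is a number 29.3 percentage points higher from compound 1 to compound 2 (beyond the scatter), which put phenyl well above cyclopropyl. Exchanging benzyl for a group with no ring is therefore expected to lower the number, and the expected step is a number 26.8 percentage points lower from compound 2 to compound 3 (beyond the scatter). Compound 3 is estimated at 30%, with a range from 10% to 55%.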

Compound 3, a percentage reported as inhibition, at one concentration (the size of the read-out at that concentration, not a potency): 17.3%
Estimate against measurement, compound 3: 12.7 percentage points above, and the stated range covers the measured number.
By their numbers in this assay, from the lowest: compound 3; then compound 1; then compound 2.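

The change to 1,1-dimethylprop-2-yn-1-yl on the amine nitrogen gives a number 39.5 percentage points lower from compound 2 to compound 3 (beyond the scatter) and a number 10.2 percentage points lower from compound 1 to compound 3 (beyond the scatter) so a substituent with no ring stands lowest of the three, with no compound shown against this. The step from benzyl changes the ring, the triple bond and the branching together, so these compounds cannot separate them. Nothing measured here accounts for the drop.

Still open, going by these compounds, is whether unbranched prop-2-yn-1-yl on this nitrogen would stand nearer compound 1 or compound 3. Also open, on these data alone, is how a longer chain ending in phenyl would compare with benzyl.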